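Demethylating the Sulfur in a Series Stuck at the Limit

A few compounds are considered here, and "the series" means these few. Any claim that something is new, unique, unknown or untested is made for them only; others in the source may bear on it.

Of the compounds shown here, three have been tested in a functional assay on KB cells (Homo sapiens) for cytotoxicity (a lower number here means that less compound is needed, a higher number that more compound is needed for the effect), and none of them produced a number. Compound 1 `Cc1ccc(S(=O)(=O)/N=c2\cc(Cl)c3ncn4c3n2C[C@H]2O[C@@H]4[C@@H]3OC(C)(C)O[C@@H]32)cc1` gives > 22 ug/mL in this assay, which is a limit of the assay rather than a measured value. Compound 2 `CSc1cc(NC(C)=O)nc2[nH]cnc12` likewise gives only the limit > 22 ug/mL in this assay. Compound 3 `CSc1cc(N)nc2c1ncn2[C@@H]1O[C@H](CO)[C@@H](O)[C@H]1O` also stops at the limit > 22 ug/mL in this assay. Where compound 3 stands is therefore known only as a limit, and the same holds for the other two values, since all three sit at the limit of > 22 ug/mL in this assay, at which 3 of the 3 values shown sit.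

Compound 4 `Nc1cc(S)c2ncn([C@@H]3O[C@H](CO)[C@@H](O)[C@H]3O)c2n1` has not yet been measured in this assay. It differs from compound 3 by hydrogen in place of methyl on a sulfur whose other neighbour is an aromatic carbon. Among the measured compounds shown here, no pair of measured compounds separated by a single change is available, so no measured step can guide the direction. The author expects the step that the limit leaves unreadable from compound 3 to compound 4 to stay within the usual scatter, because compound 3 reaches only the limit > 22 ug/mL. Compound 4 is most likely to return a limit again, and the estimated value for compound 4 in this assay is 30 ug/mL, with a range from 8 ug/mL to 110 ug/mL.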

Compound 4, concentration for half-maximal effect: > 22 ug/mL
Compound 4: a limit, no number; the forecaster's own chance of this, stated with the estimate: 70%; the middle value is on the limit's open side.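

Compound 4 gives > 22 ug/mL in this assay, which is a limit and not a number. Compound 3 also stands at a limit, and no step can be read for the change from methylsulfanyl to sulfanyl. The compounds shown leave open what change, if any, would produce a measurable value in this assay: the limit of > 22 ug/mL in this assay, at which 4 of the 4 values shown sit.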